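Amine variation on the trifluoromethylphenylsulfonyl series

The source may report more compounds than this note shows. Statements on the series, on what has been measured and on what is new or still open speak of the compounds shown alone.

Two compounds have numbers in an assay on isolated protein for inhibition of B1 bradykinin receptor (Homo sapiens); a lower number here means a stronger inhibitor, a higher number a weaker inhibitor. Compound 1 `CC(C)(C)NCc1ccc2c(c1)CCC[C@H]2NC(=O)C[C@@H]1CCCCN1S(=O)(=O)c1cccc2cnccc12` gives 610 nM in this assay. Compound 2 `CC(C)(C)CNCc1ccc2c(c1)CCC[C@H]2NC(=O)C[C@@H]1CCCCN1S(=O)(=O)c1cccc(C(F)(F)F)c1` gives 59 nM in this assay and stands lowest of the two numbers; its nearest neighbour, compound 1, sits higher by a gap beyond the scatter. Going by the values given here, compound 1 and compound 2 differ in more than one place, so their values show only that the two compounds are far apart.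

Compound 3 `CN(C)Cc1ccc2c(c1)CCC[C@H]2NC(=O)C[C@@H]1CCCCN1S(=O)(=O)c1cccc(C(F)(F)F)c1` has not yet been measured. It differs from compound 2 by dimethylamino in place of neopentylamino on a saturated chain carbon bound to an aromatic carbon, so the hydrogen-bond donor of the neopentylamino group is gone and the group is smaller. With no measured step of this kind in the series, the size of the change is uncertain. The step expected is a 3.1-fold higher number from compound 2 to compound 3 (0.48 log units; beyond the scatter), a weakening beyond the scatter. Compound 3 is estimated to give 180 nM in this assay, within a range of 45 nM to 700 nM.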

Compound 3, half-maximal inhibitory concentration: 62 nM
Beside the measured number, compound 3's estimate is 2.9-fold (0.46 log units) above it; low and high end bracket the measured number.
By their numbers in this assay, from the lowest: compounds 2 and 3 (each within the scatter of the next); then compound 1.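

In this assay, going by these compounds alone, the change to dimethylamino from neopentylamino on a saturated chain carbon bound to an aromatic carbon gives a 1.1-fold higher number from compound 2 to compound 3 (0.02 log units; within the scatter) and is the only single-place comparison so far. The group goes from 6 heavy atoms to 3 and loses its hydrogen-bond donor, so at this position, in this pair, neither that donor nor the larger neopentylamino group is needed to keep the number in this range. No measured information is at hand to explain this result.

Open, from the compounds shown here alone, is how far this holds for other groups at the same place, such as a primary amine, piperidine or a carboxylic acid. Compound 1 differs from compound 2 and compound 3 in more than one place, so its gap cannot be assigned to the amine or to the sulfonyl substituent.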